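Replacing the 2-methoxyphenyl group of compound 2

The source may report more compounds than this note shows. Statements on the series, on what has been measured and on what is new or still open speak of the compounds shown alone.

In a functional assay on M21 cells (Homo sapiens) for antiproliferative activity, read by sulforhodamine B assay, with a stated time of 48 h (a lower number here means a stronger inhibitor, a higher number a weaker inhibitor), compound 1 `Cc1ccc(OS(=O)(=O)c2ccc(N3CCN(C)C3=O)cc2)c(C)c1` gives 1800 nM, a clear growth-inhibiting effect on these cells. Compound 2 `CCCN1CCN(c2ccc(S(=O)(=O)Oc3ccccc3OC)cc2)C1=O` gives > 100000 nM, which is a limit of the assay and not a number. Compound 2 therefore stands at the weak end of what has been measured so far. Compound 3 `CCCN1CCN(c2ccc(S(=O)(=O)Oc3ccc(C)cc3C)cc2)C1=O` has 2,4-dimethylphenyl in place of 2-methoxyphenyl on an oxygen. Among the measured compounds shown here, no measured pair yet isolates this change, so any forecast is uncertain. Compound 1 also carries the 2,4-dimethylphenyl group and gives 1800 nM, which is the basis for expecting a large gain in strength in this assay, well beyond the scatter. The expected change is an at least 25-fold lower number from compound 2 to compound 3 (1.39 log units; beyond the scatter). For compound 3 the estimated value is 4000 nM, with an expected range from 700 nM to 40000 nM.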

Compound 3, half-maximal inhibitory concentration: 9700 nM
Compound 3: the middle estimate sits 2.4-fold (0.38 log units) below what was measured; the range from low to high includes it.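

In this assay, 2,4-dimethylphenyl in place of 2-methoxyphenyl on an oxygen gives an at least 10-fold lower number from compound 2 to compound 3 (1.01 log units; beyond the scatter), so the group on this oxygen matters strongly for growth inhibition. With 2,4-dimethylphenyl kept, ethyl in place of hydrogen on a saturated chain carbon bound to an amide-type nitrogen in a ring gives a 5.4-fold higher number from compound 1 to compound 3 (0.73 log units; beyond the scatter), a smaller step that shows the chain also has some effect. The full size of the first step stays unknown because compound 2 gives only a limit of the assay, not a number: the limit of > 100000 nM in this assay, at which 1 of the 3 values shown sits.

This single swap cannot tell whether the gain comes from adding the two methyl groups or from losing the methoxy group. Going by these compounds, how a plain phenyl or a pyridine ring would behave on this oxygen remains open, as does the effect of a chain carrying an amine.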